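Swapping methoxy for chloro on a weakly cytotoxic hydrazone

This account rests on a few compounds, and the source may have more. Where it says the series, first, only, none or still open, it means among the compounds named here.

Among the compounds with values here, in a functional assay on LNCaP cells (Homo sapiens) for cytotoxicity (on this read-out lower numbers stand for stronger inhibition and higher numbers for weaker inhibition), compound 1 `COc1ccc(Cn2cc(/C=N\NC(=O)c3c[nH]c4ccccc34)c3ccccc32)cc1` gives 31900 nM, the only plain number among the three measured compounds. Compound 2 `COc1ccc(Cn2cc(/C=N\NC(=O)c3c[nH]c4ccc(Br)cc34)c3cc(OC)ccc32)cc1` reaches only the limit of > 100000 nM in this assay. Compound 3 `COc1ccc(Cn2cc(/C=N\NC(=O)c3c[nH]c4ccccc34)c3ccc(F)cc32)cc1` likewise gives only the limit > 100000 nM. Within the data shown here, the one measured step, an at least 3.1-fold higher number from compound 1 to compound 3 (0.49 log units; beyond the scatter), pushes the read-out past the edge of the assay, in keeping with the limit of > 100000 nM in this assay, at which 2 of the 3 values shown sit. Compound 4 `O=C(N/N=C\c1cn(Cc2ccc(Cl)cc2)c2ccccc12)c1c[nH]c2ccccc12` differs from compound 1 in that (chloro in place of methoxy on an aromatic carbon). Among the measured compounds shown here, no measured step touches this part of the structure, so the fluoro step gives no direct guide. The expected step of a 1.1-fold lower number from compound 1 to compound 4 (0.03 log units; within the scatter) is therefore small, within the scatter, in either direction. Compound 4 is estimated at 30000 nM, expected to lie between 8000 nM and 100000 nM.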

Compound 4, half-maximal inhibitory concentration: > 100000 nM
Compound 4 was reported as a limit (the forecaster's own chance of this, stated with the estimate: 35%); middle value at least 3.3-fold (0.52 log units) from the limit.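

In this assay, going from 4-methoxybenzyl to 4-chlorobenzyl gives an at least 3.1-fold higher number from compound 1 to compound 4 (0.49 log units; beyond the scatter), so this position, which the fluoro step did not touch, also affects the read-out. For compound 4, > 100000 nM is a limit of the assay, not a number. Compound 1 therefore remains the only compound with a plain number, and the others share one edge: the limit of > 100000 nM in this assay, at which 3 of the 4 values shown sit.

On these data alone, whether any group at this position gives a lower number than methoxy stays open. An amine, a hydroxyl or a longer chain such as ethoxy would begin to answer that.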